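Fluoro for methyl on the sulfonamide ring: tolerability outlook

The compounds below may be only part of what the source reports. "The series", "measured", "known", "first", "only" and "open" are said of these compounds alone.

Measured so far in an ADME assay on HEK293 cells (Homo sapiens) for cytotoxicity, read by resazurin assay, with a stated time of 48 h; a lower number here means that less compound is tolerated, a higher number that more compound is tolerated:
compound 1 `O=S(=O)(Nc1ccc(-c2nc3ccccc3o2)cc1)c1ccc(F)c(C(F)(F)F)c1` gives 82000 nM
compound 2 `Cc1ccccc1S(=O)(=O)Nc1ccc(-c2nc3ccccc3o2)cc1` gives > 100000 nM
compound 3 `O=S(=O)(Nc1ccc2oc(-c3ccccc3)nc2c1)c1ccccc1Cl` gives 73000 nM

All three share the same core, a benzoxazole-bearing aniline carrying a sulfonamide, and differ in the ring attached to the sulfonyl group. Compound 1 and compound 3 each yield a number in this assay, and the two numbers sit close to one another. Compound 2 stands apart in that its result is not a number but a limit of the assay, > 100000 nM, which is the limit of > 100000 nM in this assay, at which 1 of the 3 values shown sits. In the numbers shown, compound 2 thus stands at the tolerated end, with no measurable toxicity up to the highest concentration tested.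

Compound 4 `O=S(=O)(Nc1ccc(-c2nc3ccccc3o2)cc1)c1ccccc1F` is the untested neighbour of compound 2. The change is fluoro in place of methyl on an aromatic carbon. Both groups are small, single heavy atoms on the same aromatic carbon, and neither adds a donor, an acceptor or a charge. No comparable exchange has been measured among these compounds, so the expectation rests on the closeness of all three results. The expected step of an at least 1.1-fold lower number from compound 2 to compound 4 (0.04 log units; that floor lies within the scatter) in this assay is none beyond the usual scatter. Compound 4 is therefore estimated at 90000 nM, with a likely range from 45000 nM to 180000 nM, and it may well again return only a limit.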

Compound 4, half-maximal cytotoxic concentration: > 100000 nM
Compound 4 was reported as a limit (the forecaster's own chance of this, stated with the estimate: 45%); at least 1.1-fold (0.04 log units) between middle value and limit.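

For the compounds shown here, compound 2 and compound 4 both return only a limit in this assay and no number, so no step between them can be read, because both results sit at the same limit: the limit of > 100000 nM in this assay, at which 2 of the 4 values shown sit.

The compounds shown leave open whether fluoro in place of methyl on an aromatic carbon changes tolerance at all at concentrations beyond that limit.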